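A few compounds are considered here, and "the series" means these few. Any claim that something is new, unique, unknown or untested is made for them only; others in the source may bear on it.

Two compounds share the same core and differ only in the group on the sulfonyl sulfur. Compound 1 `Cc1ccc(-c2ccccc2S(=O)(=O)N2CCC(N3CCC(C)CC3)CC2)cc1` carries a 4-methylphenyl there and, in a functional assay on DLD-1 cells (Homo sapiens) for antiproliferative activity, read by CellTiter-Glo, with a stated time of 72 h (on this read-out lower numbers stand for stronger inhibition and higher numbers for weaker inhibition), compound 1 gives 366 nM. Compound 2 `CC1CCN(C2CCN(S(=O)(=O)c3ccccc3Br)CC2)CC1` carries a bromo in its place, and in this assay compound 2 gives 3 nM; the step of a 120-fold lower number from compound 1 to compound 2 (2.09 log units; beyond the scatter) shows how strongly this position answers to a change. Compound 2 thus stands at the lowest of the two numbers, with compound 1 far above it.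

Compound 3 `CC1CCN(C2CCN(S(=O)(=O)c3ccc(Cl)nc3)CC2)CC1` makes the change (6-chloropyridin-3-yl in place of 2-bromophenyl on a sulfonyl sulfur). For the measured compounds named here, no measured step covers this exact exchange; the step from compound 1 to compound 2 only shows that the group on the sulfur can shift the number by a large amount. A moderate weakening is therefore expected, amounting to a 10-fold higher number from compound 2 to compound 3 (1.00 log units; beyond the scatter). Compound 3 is expected to give 30 nM, within a range of 5 nM to 200 nM.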

Compound 3, half-maximal inhibitory concentration: 3700 nM
The estimate for compound 3 lay 120-fold (2.09 log units) below the measured number, outside the stated range (above it).
By their numbers in this assay, from the lowest: compound 2; then compound 1; then compound 3.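

With the change from 2-bromophenyl to 6-chloropyridin-3-yl, this assay gives a 1200-fold higher number from compound 2 to compound 3 (3.09 log units; beyond the scatter), so this position on the sulfonyl sulfur can move the number sharply upward even from a group as small as the bromo-bearing ring. Both groups hold the same number of heavy atoms, so that count does not separate them; the entering group instead brings a ring nitrogen, a hydrogen-bond acceptor and chlorine in place of bromine. The highest number now no longer belongs to compound 1 at 366 nM, but to compound 3 at 3700 nM.

Nothing given here accounts for the size of this step. From the compounds shown here alone, the ring and the halogen change together, so it stays open which of them carries the step, and how a 2-chlorophenyl or a 6-bromopyridin-3-yl group on the sulfonyl sulfur would read.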